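The source may hold more compounds than are shown below. What is called first, only, known or untested is meant among the compounds shown, and "the series" means these compounds.

Compound 3 `Cn1cncc1CN1CC(N(Cc2cccc(-n3cccc3)c2)S(=O)(=O)c2ccccn2)Cc2cc(C#N)ccc21` gives 2.3 10^-6 cm/s in an ADME assay on Caco-2 cells (Homo sapiens) for permeability, in the apical to basolateral direction (a higher number here means that the compound crosses the layer faster, a lower number that the compound crosses the layer more slowly), the highest of the three numbers: compound 2 `CC(C)OC(=O)N1CCC(CN(C2Cc3cc(C#N)ccc3N(Cc3cncn3C)C2)S(=O)(=O)c2ccccn2)CC1` gives 1 10^-6 cm/s and compound 1 `Cn1cncc1CN1CC(N(CC2CCN(C(=O)Nc3ccc(Br)cc3)CC2)S(=O)(=O)c2ccccn2)Cc2cc(C#N)ccc21` gives 0.6 10^-6 cm/s. Compound 4 `CCS(=O)(=O)N1CCC(CN(C2Cc3cc(C#N)ccc3N(Cc3cncn3C)C2)S(=O)(=O)c2ccccn2)CC1` differs from compound 3 in one place: 1-(ethylsulfonyl)piperidin-4-yl in place of 3-(1H-pyrrol-1-yl)phenyl on a saturated chain carbon bound to a sulfonamide nitrogen. The step that bears directly on this change is a 2.3-fold higher number from compound 2 to compound 3 (0.36 log units; beyond the scatter), in which a piperidin-4-yl group of a related kind was removed. The step of a 1.7-fold higher number from compound 1 to compound 2 (0.22 log units; within the scatter) adds that two compounds carrying such a piperidin-4-yl group sit close to each other. Compound 4 is therefore expected to move back toward compound 2, with an estimated step of a 2.6-fold lower number from compound 3 to compound 4 (0.41 log units; beyond the scatter). For compound 4 the expected value in this assay is 0.9 10^-6 cm/s, in a range from 0.4 10^-6 cm/s to 2 10^-6 cm/s.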

Compound 4, apparent permeability: 0.1 10^-6 cm/s
Beside the measured number, compound 4's estimate is 9.0-fold (0.95 log units) above it; the measured number lies below the stated range.
By their numbers in this assay, from the lowest: compound 4; then compounds 1 and 2 (each within the scatter of the next); then compound 3.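

In this assay, the group on the amine nitrogen in the ring separates compounds that share the piperidin-4-yl ring: ethylsulfonyl in place of isopropoxycarbonyl gives a 10-fold lower number from compound 2 to compound 4 (1.00 log units; beyond the scatter) and ethylsulfonyl in place of (4-bromophenyl)carbamoyl gives a 6.0-fold lower number from compound 1 to compound 4 (0.78 log units; beyond the scatter) on this measure. The full exchange on the saturated chain carbon bound to a sulfonamide nitrogen gives a 23-fold lower number from compound 3 to compound 4 (1.36 log units; beyond the scatter) and is the largest step in the set.

As far as these compounds go, whether the low number follows the sulfonyl or its ethyl chain stays open, as no methylsulfonyl or phenylsulfonyl group stands on that nitrogen here. No evidence accounts for this fall.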